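The source may hold more compounds than are shown below. What is called first, only, known or untested is meant among the compounds shown, and "the series" means these compounds.

Three compounds share one core, a six-membered ring bearing two nitrogens and carrying a chain with two hydroxy groups, and differ only at one aromatic carbon of that ring. Compound 1 `O=c1ccn(COC(CO)CO)c(=O)[nH]1` carries a hydrogen there. In a functional assay on SW-620 cells (Homo sapiens) for inhibition, read by MTT assay, with a stated time of 72 h (on this read-out higher numbers stand for weaker inhibition and lower numbers for stronger inhibition), compound 1 gives > 100000 nM, which is a limit of the assay and not a number. Compound 2 `Nc1cn(COC(CO)CO)c(=O)[nH]c1=O` carries an amino group in the same place; in this assay compound 2 gives > 100000 nM, again a limit rather than a number. Going by the values given here, compound 3 `O=C(CCl)Nc1cn(COC(CO)CO)c(=O)[nH]c1=O` carries a ((chloromethyl)carbonyl)amino group, and in this assay compound 3 gives 19000 nM, the only actual number among the three. Of the three values, two sit at one limit (the limit of > 100000 nM in this assay, at which 2 of the 3 values shown sit). The step from compound 1 to compound 3 is an at least 5.2-fold lower number from compound 1 to compound 3 (0.72 log units; beyond the scatter), and the step from compound 2 to compound 3 is an at least 5.2-fold lower number from compound 2 to compound 3 (0.72 log units; beyond the scatter); the step between compound 1 and compound 2 is a step that the two limits leave unreadable from compound 1 to compound 2.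

Compound 4 `O=c1[nH]c(=O)n(COC(CO)CO)cc1O` makes this change from compound 3: hydroxy in place of ((chloromethyl)carbonyl)amino on an aromatic carbon. The (chloromethyl)carbonyl that distinguished compound 3 from compound 2 is gone, and a hydroxy stands where compounds 1 and 2 carry hydrogen or amino. The measured steps from compound 2 to compound 3 and from compound 1 to compound 3 both point the same way, so removing that group is expected to raise the number back toward the limit. Compound 4 is therefore estimated at 100000 nM, in a range from 30000 nM to 300000 nM. This estimate means an expected step of a 5.3-fold higher number from compound 3 to compound 4 (0.72 log units; beyond the scatter).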

Compound 4, half-maximal inhibitory concentration: > 100000 nM
Compound 4 gave a limit, no number; the forecaster's own chance of this, stated with the estimate: 70%; the middle value lies on the limit itself.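

In this assay, going by these compounds alone, the ((chloromethyl)carbonyl)amino group remains the only group at this aromatic carbon that gives an actual number, and replacing it with hydroxy produces an at least 5.2-fold higher number from compound 3 to compound 4 (0.72 log units; beyond the scatter). Hydroxy thus joins hydrogen and amino as a third group at this place that leaves the value at the limit, so the readable value now stands apart from three different replacements. The steps from compound 1 to compound 4 and from compound 2 to compound 4 cannot be read, since both ends of each are limits, and hydrogen, amino and hydroxy therefore cannot be ranked against one another; the evidence for this is a single shared ceiling: the limit of > 100000 nM in this assay, at which 3 of the 4 values shown sit.

What the compounds shown leave open is which part of the ((chloromethyl)carbonyl)amino group carries the difference, the chlorine or the amide-linked carbonyl. An acetylamino group, which keeps the carbonyl and lacks the chlorine, or a (bromomethyl)carbonylamino group, which swaps chlorine for bromine, at this same aromatic carbon would separate those two parts.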